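Adding a Methoxy Group to Compound 1

The compounds below may be only part of what the source reports. "The series", "measured", "known", "first", "only" and "open" are said of these compounds alone.

Compound 1 `COc1cc(/C=C2\CN(C)C/C(=C\c3ccc(F)cc3)C2=O)cc(OC)c1`: 6140 nM
Compound 2 `COc1cc(/C=C2\CN(C)C/C(=C\c3ccc(Cl)cc3Cl)C2=O)cc(OC)c1`: 6250 nM

In a functional assay on HepG2 cells (Homo sapiens) for cytotoxicity, read by MTT assay, with a stated time of 24 h (on this read-out higher numbers stand for weaker inhibition and lower numbers for stronger inhibition), compound 1 gives 6140 nM. Going by the values given here, only one other measurement stands beside it, and the two cannot be separated: a 1.0-fold higher number from compound 1 to compound 2 (0.01 log units; within the scatter). Compound 3 `COc1cc(/C=C2\CN(C)C/C(=C\c3ccc(F)cc3)C2=O)cc(OC)c1OC` keeps the core of compound 1 and carries one change, methoxy in place of hydrogen on an aromatic carbon. Among the compounds with values here, no measured step touches this place. Within the data shown here, the one available step replaces the 4-fluorophenyl group with 2,4-dichlorophenyl, so it bears on the new change only indirectly. Among the measured compounds shown here, compound 2, at 6250 nM, shows only that one substantial change elsewhere left the number within the scatter. No firm direction can be drawn from this, so in this assay the expected change is small: a 1.1-fold lower number from compound 1 to compound 3 (0.05 log units; within the scatter). For compound 3 the estimated value is 5500 nM, with an expected range of 2300 nM to 12000 nM.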

Compound 3, half-maximal inhibitory concentration: 7340 nM
Beside the measured number, compound 3's estimate is 1.3-fold (0.13 log units) below it; low and high end bracket the measured number.
By their numbers in this assay, from the lowest: compounds 1, 2 and 3 (each within the scatter of the next).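

Going by these compounds alone, this is the first measured change at this position, an aromatic carbon ortho to two methoxy groups and para to a large group. In this assay, methoxy in place of hydrogen gives a 1.2-fold higher number from compound 1 to compound 3 (0.08 log units; within the scatter), so for this one pair, a group of 2 heavy atoms where only a hydrogen stood leaves the number indistinguishable from that of compound 1. No measurement at hand offers an explanation for this result.

On these data alone, whether a different group at this position, such as an amine, a carboxylic acid or a longer chain like ethoxy, would shift the number remains open. As far as these compounds go, it is also open whether methoxy here would give the same result with the 2,4-dichlorophenyl group of compound 2 in place of the 4-fluorophenyl group.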